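This account rests on a few compounds, and the source may have more. Where it says the series, first, only, none or still open, it means among the compounds named here.

Working notes on the series. Compound 2 `O=C(CCCl)Nc1ccc2[nH]c(-c3ccc(Br)cc3)nc2c1` gives 11300 nM in a functional assay on HepG2 cells (Homo sapiens) for cytotoxicity, read by MTT assay, with a stated time of 72 h; on this read-out lower numbers stand for stronger inhibition and higher numbers for weaker inhibition; compound 1 `CCN1CCN(CCC(=O)Nc2ccc3[nH]c(-c4ccc(C)cc4)nc3c2)CC1` gives 14600 nM, and the two values lie within the scatter of each other, so neither stands apart. Compound 3 `Cc1ccc(-c2nc3cc(NC(=O)CCCl)ccc3[nH]2)cc1` is not yet measured. It differs from compound 2 by methyl in place of bromo on an aromatic carbon. Among the measured compounds shown here, no measured pair shows this exchange alone, so no step beyond the scatter is expected in either direction. Compound 3 is estimated at 13000 nM with a range of 5000 nM to 35000 nM. The expected step of a 1.2-fold higher number from compound 2 to compound 3 (0.06 log units; within the scatter) stays within the scatter.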

Compound 3, half-maximal inhibitory concentration: > 50000 nM
Compound 3 was reported as a limit; the forecaster's own chance of this, stated with the estimate: 10%; at least 3.8-fold (0.58 log units) between middle value and limit.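

Replacing 4-bromophenyl with 4-methylphenyl is not a neutral exchange in this assay: the change gives an at least 4.4-fold higher number from compound 2 to compound 3 (0.64 log units; beyond the scatter). With 4-methylphenyl held constant, chloro in place of 4-ethylpiperazin-1-yl on the chain gives an at least 3.4-fold higher number from compound 1 to compound 3 (0.53 log units; beyond the scatter), so the chain end also counts in this setting. Compound 3 stands as a limit, and both steps are only lower bounds: the limit of > 50000 nM in this assay, at which 1 of the 3 values shown sits.

From the compounds shown here alone, the true size of either step stays open. Also open, going by these compounds, are how a methoxy group or a fluorine atom at the bromo position would read, and how 4-ethylpiperazin-1-yl would read alongside 4-bromophenyl.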